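The compounds below may be only part of what the source reports. "The series", "measured", "known", "first", "only" and "open" are said of these compounds alone.

Of the compounds shown here, two built on a shared core have been measured so far in an ADME assay on cells (Homo sapiens) for cytotoxicity, read by polymerase chain reaction, with a stated time of 3 days; on this read-out higher numbers stand for lower toxicity in this test and lower numbers for higher toxicity in this test. Compound 1 (`Cc1nc(N(C)C)nc(N[C@@H]2C[C@H](CO)[C@@H](O)[C@H]2O)c1-c1nc2cnccc2s1`), which carries dimethylamino on an aromatic carbon, gives 25000 nM. Among the compounds with values here, compound 2 (`Cc1nc(NCC2CCN(C)CC2)nc(N[C@@H]2C[C@H](CO)[C@@H](O)[C@H]2O)c1-c1nc2cnccc2s1`), which carries ((1-methylpiperidin-4-yl)methyl)amino in its place, gives 25000 nM, so it stands level with compound 1, its only measured neighbour. Compound 3 (`Cc1nc(N[C@H](C)c2ccccc2)nc(N[C@@H]2C[C@H](CO)[C@@H](O)[C@H]2O)c1-c1nc2cnccc2s1`) has not yet been measured. It differs from compound 2 as follows: 1-phenylethyl in place of (1-methylpiperidin-4-yl)methyl on a nitrogen on an aromatic ring. In words, 1-phenylethyl stands in place of (1-methylpiperidin-4-yl)methyl on a nitrogen on an aromatic ring. Within the data shown here, one measured step bears on this change, no change at the digits printed from compound 1 to compound 2 (within the scatter), and it stayed within the scatter. That evidence is thin, since neither compound 1 nor compound 2 carries the aromatic ring that now enters, and a move towards lower numbers in this assay cannot be excluded. Even so, no shift beyond the scatter is expected, and the estimated step is a 1.1-fold lower number from compound 2 to compound 3 (0.06 log units; within the scatter). Compound 3 is expected to give 22000 nM, with an estimated range of 10000 nM to 32000 nM.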

Compound 3, half-maximal cytotoxic concentration: 25000 nM
Beside the measured number, compound 3's estimate is 1.1-fold (0.06 log units) below it; the range from low to high includes it.
By their numbers in this assay, from the lowest: compounds 1, 2 and 3 (each within the scatter of the next).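

In this assay, putting 1-phenylethyl in place of (1-methylpiperidin-4-yl)methyl on a nitrogen on an aromatic ring gives no change at the digits printed from compound 2 to compound 3 (within the scatter), and the wider exchange of dimethylamino for (1-phenylethyl)amino on an aromatic carbon gives no change at the digits printed from compound 1 to compound 3 (within the scatter). The earlier compounds had shown only that dimethylamino and ((1-methylpiperidin-4-yl)methyl)amino read alike, whereas this result extends that to a group with a six-membered aromatic ring of carbon only and a defined stereocentre, and with the hydrogen-bond acceptor of the leaving group gone. Nothing available here accounts for why the read-out stays level across these three groups.

From the compounds shown here alone, it remains open whether any group at this place can move the numbers in this assay, for instance a carboxylic acid on the nitrogen substituent or a longer chain ending in a primary amine. The compounds shown also leave open whether the other mirror form of 1-phenylethyl, or a chlorine or a methoxy group on its phenyl ring, would read the same.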